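Serum half-life: from compound 3 to compound 4

The source may hold more compounds than are shown below. What is called first, only, known or untested is meant among the compounds shown, and "the series" means these compounds.

Among the measured compounds shown here, in an ADME assay on a cell-free system (serum) for metabolic stability (a lower number here means that the compound disappears faster, a higher number that the compound lasts longer), compound 1 (`CC(C)(C)c1cc(OC(=O)c2ccc(Cl)cc2Cl)ccc1O`) gives 0.167 h, the only reading in this set that is a number rather than a limit. Compound 2 (`COc1ccc(NC(=O)c2ccc(Cl)cc2Cl)cc1C(C)(C)C`) reads > 1 h, which is a limit of the assay. Compound 3 (`CC(C)(C)c1cc(NC(=O)c2c(Cl)cc(NCc3ccncc3)cc2Cl)ccc1O`) reads > 1 h, which is also a limit. Going by these compounds, compound 3 therefore stands at the limit of > 1 h in this assay, at which 2 of the 3 values shown sit, and its actual half-life remains unknown.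

Compound 4 (`CC(C)(C)c1cc(NC(=O)c2c(Cl)cc(NC3CCCCC3)cc2Cl)ccc1O`) carries cyclohexyl in place of (pyridin-4-yl)methyl on a nitrogen on an aromatic ring. For the measured compounds named here, no measured pair in the set shows this change, so the only guide is compound 3 at > 1 h. No step beyond the scatter is expected in this assay, and neither direction is favoured. The estimated step that the limit leaves unreadable from compound 3 to compound 4 is expected to stay small. For compound 4 the expected half-life is 1.5 h, with an estimated range of 0.7 h to 5 h.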

Compound 4, half-life: > 1 h
Compound 4: no number, only a limit; the forecaster's own chance of this, stated with the estimate: 80%; the middle value is on the limit's open side.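

In this assay, compound 3 and compound 4 both sit at a limit of the assay, so no step can be read between them: the limit of > 1 h in this assay, at which 3 of the 4 values shown sit.

Going by these compounds, the actual half-lives of compound 3 and compound 4 stay open, and with them any difference between (pyridin-4-yl)methyl and cyclohexyl on a nitrogen on an aromatic ring.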